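An amide change from compound 1 to compound 4

The source may report more compounds than this note shows. Statements on the series, on what has been measured and on what is new or still open speak of the compounds shown alone.

Compound 1 `C[C@H](Nc1ncnc(N)c1C#N)c1nc2ccc(F)cc2c(C(N)=O)c1-c1ccccc1` stands in an ADME assay on microsomes from liver (Rattus norvegicus) for pharmacokinetics, using NADPH, with a stated time of 30 min, tested at 1 uM (on this read-out lower numbers stand for slow clearance and higher numbers for fast clearance), with a result known only as a limit. Compound 1 gives < 14 mL.min-1.g-1 as a limit of the assay and not as a number. Compound 2 `CCNC(=O)c1c(-c2ccccc2)c([C@H](C)Nc2ncnc(N)c2C#N)nc2ccc(F)cc12` carries an ethyl on the amide nitrogen and gives < 14 mL.min-1.g-1 as a limit too. Compound 3 `CC(C)NC(=O)c1c(-c2ccccc2)c([C@H](C)Nc2ncnc(N)c2C#N)nc2ccc(F)cc12` carries an isopropyl there and gives < 14 mL.min-1.g-1 as a limit too. Across these compounds the record reads the limit of < 14 mL.min-1.g-1 in this assay, at which 3 of the 3 values shown sit, and holds no exact number.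

Compound 4 `C[C@H](Nc1ncnc(N)c1C#N)c1nc2ccc(F)cc2c(C(=O)N2CC(O)C2)c1-c1ccccc1` is still unmeasured. It differs from compound 1 by 3-hydroxyazetidin-1-yl in place of amino on a carbonyl carbon and so has 3-hydroxyazetidin-1-yl in place of amino on a carbonyl carbon. The nearest measured changes are a step that the two limits leave unreadable from compound 1 to compound 2 and a step that the two limits leave unreadable from compound 1 to compound 3 and also a step that the two limits leave unreadable from compound 2 to compound 3 and none of them offers a size. The expectation that the read-out stays low in this assay rests on compound 3 with its limit of < 14 mL.min-1.g-1 as the most substituted amide measured. The expected step is a step that the limit leaves unreadable from compound 1 to compound 4 with no direction claimed beyond the scatter. Compound 4 is estimated at 10 mL.min-1.g-1 with an expected range from 5 mL.min-1.g-1 to 20 mL.min-1.g-1 and the assay may well report only a limit again.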

Compound 4, intrinsic clearance in microsomes: 49 mL.min-1.g-1
Compound 4: middle estimate off by 4.9-fold (0.69 log units), on the low side; measured number outside the range, above it.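

In this assay, the group on this carbonyl carbon proves able to move the read-out: 3-hydroxyazetidin-1-yl in place of amino gives an at least 3.5-fold higher number from compound 1 to compound 4 (0.54 log units; beyond the scatter). The same holds when the comparison starts from either substituted amide, with an at least 3.5-fold higher number from compound 2 to compound 4 (0.54 log units; beyond the scatter) for 3-hydroxyazetidin-1-yl in place of ethylamino and an at least 3.5-fold higher number from compound 3 to compound 4 (0.54 log units; beyond the scatter) for 3-hydroxyazetidin-1-yl in place of isopropylamino, so the rise is seen from all three starting points. Compound 4 is the only compound here that stands clear of the limit shared by compound 1, compound 2 and compound 3, whose steps among themselves cannot be read: the limit of < 14 mL.min-1.g-1 in this assay, at which 3 of the 4 values shown sit.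

Going by these compounds, the true size of the rise stays open, as does the question of whether it goes with the four-membered ring, with the hydroxy group on that ring, or with the change from a nitrogen carrying hydrogen to one carrying two carbons. A plain azetidin-1-yl without the hydroxy group, or an open-chain dimethylamino on the same carbonyl carbon, would bear on that question.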